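Methoxy to Hydroxy: Expected Effect on Growth Inhibition

A few compounds are considered here, and "the series" means these few. Any claim that something is new, unique, unknown or untested is made for them only; others in the source may bear on it.

Of the compounds shown here, two have so far been tested in a functional assay on UACC-257 cells (Homo sapiens) for inhibition, read by sulforhodamine B assay, with a stated time of 48 h; on this read-out higher numbers stand for weaker inhibition of growth and lower numbers for stronger inhibition of growth. Compound 1 `Cc1cc(O)cc(-c2nn(CC#N)cc2-c2ccnc(-c3ccc(Oc4ccccc4)cc3)c2)c1` gives 8380 nM. Compound 2 `COc1cc(C)cc(-c2nn(CC#N)cc2-c2ccnc(-c3ccc(N(C)C)cc3)c2)c1` gives only a limit of the assay, > 100000 nM. Compound 3 `Cc1cc(O)cc(-c2nn(CC#N)cc2-c2ccnc(-c3ccc(N(C)C)cc3)c2)c1` has not yet been measured; it differs from compound 2 by hydrogen in place of methyl on an oxygen on an aromatic ring, and thereby carries the same hydroxy group as compound 1. Because (the limit of > 100000 nM in this assay, at which 1 of the 2 values shown sits), the size of the step from compound 2 cannot be read from the numbers. The step from compound 2 to compound 3 is expected to be an at least 2.5-fold lower number from compound 2 to compound 3 (0.39 log units; beyond the scatter), towards stronger inhibition. Compound 3 is therefore estimated at 40000 nM, with a likely range from 8000 nM to 200000 nM.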

Compound 3, concentration for total growth inhibition: 35600 nM
Estimate against measurement, compound 3: 1.1-fold (0.05 log units) above; the measured number falls inside the stated range.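

In this assay, hydroxy in place of methoxy on the aromatic ring gives an at least 2.8-fold lower number from compound 2 to compound 3 (0.44 log units; beyond the scatter), so this change at this position moves the read-out towards stronger inhibition when dimethylamino is present. The true size of that step cannot be read because compound 2 stands at a limit of the assay: the limit of > 100000 nM in this assay, at which 1 of the 3 values shown sits. With hydroxy kept, dimethylamino in place of phenoxy gives a 4.2-fold higher number from compound 1 to compound 3 (0.63 log units; beyond the scatter), so the change at that other place also shifts the number.

From the compounds shown here alone, whether methoxy to hydroxy has a similar effect alongside phenoxy remains open. So does the effect of an amine or an ethoxy group in place of hydroxy.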